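The compounds below may be only part of what the source reports. "The series", "measured", "known", "first", "only" and "open" are said of these compounds alone.

Compound 1 `Nc1cc(N)c2nc(-c3ccccc3)c(Oc3ccc(Cl)c(Cl)c3)nc2c1` carries a 3,4-dichlorophenoxy group on the shared core. In a functional assay on NCI-H460 cells (Homo sapiens) for inhibition, read by sulforhodamine B assay, with a stated time of 48 h (a lower number here means a stronger inhibitor of growth, a higher number a weaker inhibitor of growth), compound 1 gives 18200 nM. Compound 2 `CCOC(=O)[C@H](CCC(=O)O)NC(=O)c1ccc(CNc2nc3cc(N)cc(N)c3nc2-c2ccccc2)cc1`, built on the same core with a larger side chain, gives 31600 nM in this assay; the two numbers lie within the usual scatter of each other, so neither compound can be set ahead of the other on these data. Compound 3 `Nc1cc(N)c2nc(-c3ccccc3)c(Oc3ccc(F)cc3)nc2c1` has not yet been measured. It differs from compound 1 in one place: 4-fluorophenyl in place of 3,4-dichlorophenyl on an oxygen on an aromatic ring. Among the compounds with values here, no measured pair tracks this particular swap, so the data do not settle the direction of the step. The expected step in this assay is a 1.4-fold higher number from compound 1 to compound 3 (0.14 log units; within the scatter), small and with no clear move beyond the scatter. Compound 3 is therefore estimated at 25000 nM in this assay, in a range from 8000 nM to 80000 nM.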

Compound 3, concentration for 50% growth inhibition: 39800 nM
Compound 3: the middle estimate sits 1.6-fold (0.20 log units) below what was measured, and the stated range covers the measured number.
By their numbers in this assay, from the lowest: compounds 1, 2 and 3 (each within the scatter of the next, the first and the last beyond it).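

In this assay, within the data shown here, the swap of 3,4-dichlorophenyl for 4-fluorophenyl on the oxygen gives the first readable step at this place, with a 2.2-fold higher number from compound 1 to compound 3 (0.34 log units; beyond the scatter). The group on this oxygen therefore affects growth inhibition, and the move is away from stronger inhibition, though the step is modest and rests on a single pair. Nothing available bears on why the number rises with this change.

The step replaces the whole substitution pattern at once, so the compounds shown cannot separate the part played by either chlorine from that of the fluorine. As far as these compounds go, how 4-chlorophenyl, 3-chlorophenyl or unsubstituted phenyl would read on this oxygen stays open, as does the effect of a methoxy group or a carboxylic acid on that ring.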